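The source may hold more compounds than are shown below. What is called first, only, known or untested is meant among the compounds shown, and "the series" means these compounds.

Measured compounds in the series:

compound 1 `Nc1nc(-c2ccc(Cl)cc2)nn1-c1ncnc2cc(Cl)ccc12` — 5000 nM
compound 2 `COc1cc2ncnc(-n3nc(-c4ccccn4)nc3N)c2cc1OCCCN(C)C` — 53000 nM

In a physicochemical assay for solubility, in phosphate buffer, with a stated time of 18 h, at pH 7.4 (on this read-out lower numbers stand for lower solubility and higher numbers for higher solubility), compound 2 gives 53000 nM, the highest of the two numbers. Compound 1 gives 5000 nM in this assay, a gap that lies beyond the usual scatter. The two compounds differ in more than one place, so no single step can be read from that gap; it only shows the spread of the numbers seen so far.

The next compound, compound 3 `CCCCCCOC(=O)NCCCOc1cc2c(-n3nc(-c4ccccn4)nc3N)ncnc2cc1OC`, is reached from compound 2 by one change: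

(hexyloxycarbonyl)amino in place of dimethylamino on a saturated chain carbon, three bonds along the chain from an oxygen on an aromatic ring

Going by the values given here, no step between measured compounds is known for this change, and none of the measured pairs isolates it. The expectation therefore rests on compound 2 alone as the starting point, at 53000 nM, and on the size of the group that enters against the group that leaves. A downward step in this assay is expected, of a size clearly beyond the scatter rather than a flat result.

For compound 3 the expected value in this assay is 4000 nM, with a range of 800 nM to 20000 nM, which corresponds to an expected step of a 13-fold lower number from compound 2 to compound 3 (1.12 log units; beyond the scatter).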

Compound 3, solubility: 1000 nM
The estimate for compound 3 lay 4.0-fold (0.60 log units) above the measured number, within the range that was stated.
By their numbers in this assay, from the lowest: compound 3; then compound 1; then compound 2.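

At the saturated chain carbon three bonds along the chain from an oxygen on an aromatic ring, the series now has its first single-change step: in this assay the replacement of dimethylamino by (hexyloxycarbonyl)amino gives a 53-fold lower number from compound 2 to compound 3 (1.72 log units; beyond the scatter) with the rest of the structure held constant. The read-out at this position is therefore not indifferent to what stands at the chain end, and this one change is enough to produce a large step. No supporting measurement bears on why the number moves, so the step stands as an observation only.

The change alters several things at once, since the entering group brings more heavy atoms, a double bond outside aromatic rings and a hydrogen-bond donor, and the compounds shown do not separate these contributions. A shorter (methoxycarbonyl)amino group, a plain hexylamino group or a carboxylic acid on the same chain carbon would help show whether the step follows the length of the hexyl chain, the carbamate link or the loss of dimethylamino itself.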